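A few compounds are considered here, and "the series" means these few. Any claim that something is new, unique, unknown or untested is made for them only; others in the source may bear on it.

Compound 1 `O=C(/C=C/c1ccc(Br)cc1)Nc1cc2c(Nc3ccc(F)c(Cl)c3)ncnc2cc1O[C@H]1CCOC1` is one of three compounds that share a core and differ in the aryl ring carried on the double-bonded chain. In a functional assay on A549 cells (Homo sapiens) for cytotoxicity, read by MTT assay, with a stated time of 72 h (on this read-out higher numbers stand for weaker inhibition and lower numbers for stronger inhibition), compound 1 gives 35300 nM, the highest of the three numbers. Compound 3 `COc1cc2ncnc(Nc3ccc(F)c(Cl)c3)c2cc1NC(=O)/C=C/c1ccccc1[N+](=O)[O-]` gives 33300 nM in this assay, which lies within the scatter of compound 1. Compound 2 `COc1ccc(OC)c(/C=C/C(=O)Nc2cc3c(Nc4ccc(F)c(Cl)c4)ncnc3cc2OC)c1` gives 11200 nM, a number beyond the scatter below compound 1, and it is the only one of the three that stands apart.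

Compound 4 `COc1ccc(/C=C/C(=O)Nc2cc3c(Nc4ccc(F)c(Cl)c4)ncnc3cc2O[C@H]2CCOC2)cc1` differs from compound 1 by methoxy in place of bromo on an aromatic carbon.

Among the compounds with values here, only one measured step changes the same aryl ring: a 3.0-fold higher number from compound 2 to compound 3 (0.47 log units; beyond the scatter). That step swapped 2-nitrophenyl for 2,5-dimethoxyphenyl, not bromo for methoxy, so it speaks to this change only loosely, showing that a change on that ring moved the number by a modest amount. Since compound 2, whose ring carries methoxy groups, gives the lowest number, a modest step toward a lower number is expected, though a result within the scatter would not surprise. Compound 4 is therefore expected to give 20000 nM, within 7000 nM to 55000 nM, amounting to an estimated 1.8-fold lower number from compound 1 to compound 4 (0.25 log units; within the scatter).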

Compound 4, half-maximal inhibitory concentration: 3050 nM
Compound 4: middle estimate off by 6.6-fold (0.82 log units), on the high side; measured number below the stated range.
By their numbers in this assay, from the lowest: compound 4; then compound 2; then compounds 3 and 1 (each within the scatter of the next).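

In this assay, exchanging bromo for methoxy gives a 12-fold lower number from compound 1 to compound 4 (1.06 log units; beyond the scatter), which shows that a single group on an aromatic carbon, para to a large group, can shift the number by a large amount while the rest of compound 1 stays the same. Within the data shown here, the only earlier step on this ring, a 3.0-fold higher number from compound 2 to compound 3 (0.47 log units; beyond the scatter), was modest and replaced one whole substitution pattern with another, so it could not show what one group at this place does on its own. No measurement is available here that would explain the size of this step.

The compounds shown leave open whether methoxy lowers the number or bromo raises it, since an unsubstituted phenyl ring at the end of the chain would be needed to separate the two, and whether an ethoxy group, a hydroxyl or an amine at the same place would follow methoxy or bromo. They also leave open whether the same exchange would produce a step of this size on the core of compound 2, which carries a different group from compound 1.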